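Toward a longer half-life from a low limit

The source may report more compounds than this note shows. Statements on the series, on what has been measured and on what is new or still open speak of the compounds shown alone.

Measured so far in an ADME assay on microsomes from liver (Rattus norvegicus) for metabolic stability; a lower number here means that the compound disappears faster, a higher number that the compound lasts longer:
compound 1 `CC(C)C(CC1C(=O)NC(=O)N1C)c1ccc(-c2ccc3cccc(F)c3c2)[nH]c1=O`: < 0.0667 h
compound 2 `CCC(/C=C1\OC(=O)NC1=O)(CC)c1ccc(-c2ccc3cccc(C(C)C)c3c2)[nH]c1=O`: 1.88 h
compound 3 `CCC(/C=C1\OC(=O)NC1=O)(CC)c1ccc(-c2ccc3cc(F)cc(F)c3c2)[nH]c1=O`: > 3 h

Compound 1 sits at the limit of < 0.0667 h in this assay, at which 1 of the 3 values shown sits. This reading is a limit and not a number. Compound 3 also gives only a limit, > 3 h. Compound 4 `C/C(=C1/OC(=O)NC1=O)C(c1ccc(-c2ccc3cccc(F)c3c2)[nH]c1=O)C(C)C` differs from compound 1 in one place: a group of 9 heavy atoms (5 carbon, 1 nitrogen, 3 oxygen; one five-membered non-aromatic ring with 2 hetero atoms) in place of a group of 9 heavy atoms (5 carbon, 2 nitrogen, 2 oxygen; one five-membered non-aromatic ring with 2 hetero atoms), on a saturated chain carbon bound to an aromatic carbon and a saturated chain carbon. Compound 2, which carries a closely similar five-membered non-aromatic ring, gives 1.88 h, so a rise in this assay well beyond the scatter is expected. The expected size of the change is an at least 14-fold higher number from compound 1 to compound 4 (1.17 log units; beyond the scatter). For compound 4 the estimated half-life is 1 h, with an expected range from 0.2 h to 3 h.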

Compound 4, half-life: > 3 h
Compound 4: a limit, no number; the forecaster's own chance of this, stated with the estimate: 25%; at least 3.0-fold (0.47 log units) between middle value and limit.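

In this assay, among the compounds shown here, the entering group on the saturated chain carbon bound to an aromatic carbon and a saturated chain carbon gives an at least 44-fold higher number from compound 1 to compound 4 (1.65 log units; beyond the scatter), the first step here that isolates a single place on the shared core. With the core otherwise unchanged, this place alone can move the half-life by a large margin. Compound 4 gives a limit and not a number: the limit of > 3 h in this assay, at which 2 of the 4 values shown sit.

Which feature of the entering group carries the step stays open, as it differs from the group it replaces in both ring atoms and double bonds. Also open, as far as these compounds go, is how a carboxylic acid at this place would read in this assay.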